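A few compounds are considered here, and "the series" means these few. Any claim that something is new, unique, unknown or untested is made for them only; others in the source may bear on it.

The measured compounds:
Compound 1, `OC[C@@H]1C[C@H](CO)[C@@H]2C(c3ccccc3Cl)=NO[C@H]12`, in a functional assay on HeLa cells (Homo sapiens) for cytotoxicity, read by MTT assay, with a stated time of 48 h (a higher number here means a weaker inhibitor, a lower number a stronger inhibitor), gives > 50 ug/mL, which is a limit of the assay and not a number.
Compound 2, `COc1ccc(C2=NO[C@@H]3[C@H](CO)C[C@H](CO)[C@H]23)cc1OC`, in this assay gives > 50 ug/mL, again a limit rather than a number.
Compound 3, `COc1ccc(C2=NO[C@@H]3[C@H](CO)C[C@H](CO)[C@H]23)cc1`, in this assay gives > 50 ug/mL, also a limit and not a number.

Compound 3 therefore stands where the other two stand: at the limit of this assay, with no number to set it apart from either of them. Among the compounds with values here, the one change that could be followed among the measured compounds, a step that the two limits leave unreadable from compound 2 to compound 3, cannot be read in size because both of its ends sit at the limit of > 50 ug/mL in this assay, at which 3 of the 3 values shown sit.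

Compound 4, `OC[C@@H]1C[C@H](CO)[C@@H]2C(c3ccc(Br)cc3)=NO[C@H]12`, differs from compound 3 by bromo in place of methoxy on an aromatic carbon. Within the data shown here, no measured step bears directly on bromo in place of methoxy; the only step available, from compound 2 to compound 3, is itself unreadable. The account rests, then, on three values that all sit at the limit, and nothing among them points to a change that the scatter would not cover.

For compound 4 the estimate is 50 ug/mL, with a range from 20 ug/mL to 120 ug/mL. The step that this estimate implies, a number no higher from compound 3 to compound 4 (the limit leaves the size open), is expected to be none beyond the scatter, and a limit rather than a number is the likelier report.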

Compound 4, half-maximal inhibitory concentration: > 50 ug/mL
Compound 4: no number, only a limit; the forecaster's own chance of this, stated with the estimate: 75%; the middle value lies on the limit itself.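

In this assay compound 4 gives > 50 ug/mL as a limit and not a number. No new step can be read from compound 3 to compound 4, since both stand at the same limit: the limit of > 50 ug/mL in this assay, at which 4 of the 4 values shown sit. The compounds shown leave open what number any of them would give, and whether any change on the aromatic ring would bring a value inside the range of this assay.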